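The source may report more compounds than this note shows. Statements on the series, on what has been measured and on what is new or still open speak of the compounds shown alone.

Measured compounds:
- compound 1, `COc1cc2c(Nc3nc4ccc(C(=O)Nc5c(C)cccc5C)cc4s3)ncnc2cc1OCCCN1CCCC1`: in a functional assay on DLD-1 cells (Homo sapiens) for cytotoxicity, read by WST assay, with a stated time of 72 h (on this read-out lower numbers stand for stronger inhibition and higher numbers for weaker inhibition), compound 1 gives only a limit, > 100000 nM.
- compound 2, `COc1cc2c(Nc3nc4ccc(C(=O)Nc5c(C)cc(C)cc5C)cc4s3)ncnc2cc1OCCCN1CCCCC1`: in this assay compound 2 gives 24500 nM.

Compound 2 is the only one of the two with a number rather than a limit; the other value, that of compound 1, is a limit of this assay, and (the limit of > 100000 nM in this assay, at which 1 of the 2 values shown sits), so nothing further can be said about how the two stand against each other.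

Compound 3, `COc1cc2c(Nc3nc4ccc(C(=O)Nc5c(C)cc(C)cc5C)cc4s3)ncnc2cc1OCCCN1CCCC1`, has not yet been tested. It differs from compound 2 in one place: pyrrolidin-1-yl in place of piperidin-1-yl on a saturated chain carbon, three bonds along the chain from an oxygen on an aromatic ring. The rest of the molecule, including the shared core and the trimethyl-substituted amide, is unchanged. Among the compounds with values here, no pair of measured compounds shows this exchange, so there is no measured step to lean on.

Given that the change is a small one between two saturated rings of similar kind, compound 3 is expected to land close to compound 2, with a step of a 1.2-fold higher number from compound 2 to compound 3 (0.09 log units; within the scatter) that would not stand out from the usual scatter. The estimate for compound 3 in this assay is therefore 30000 nM, within a range of 10000 nM to 100000 nM.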

Compound 3, half-maximal inhibitory concentration: 5900 nM
Beside the measured number, compound 3's estimate is 5.1-fold (0.71 log units) above it; the measured number lies below the stated range.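

In this assay, the exchange of a six-membered ring for a five-membered one at the end of the chain is not a silent change: pyrrolidin-1-yl in place of piperidin-1-yl gives a 4.2-fold lower number from compound 2 to compound 3 (0.62 log units; beyond the scatter), so the amine ring on this chain has a real bearing on the read-out, even though both rings carry the same counts of donors and acceptors. Compound 3 also opens a second comparison, in another part of the molecule, where methyl in place of hydrogen on an aromatic carbon gives an at least 16-fold lower number from compound 1 to compound 3 (1.22 log units; beyond the scatter), which sets a compound with a real number against one without. Compound 1 gives only a limit, so the full size of that second step stays unknown: the limit of > 100000 nM in this assay, at which 1 of the 3 values shown sits.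

The compounds shown leave open why the smaller ring gives the lower number, and whether the same exchange would have the same effect with a different substitution on the amide. They also leave open how other amines at the end of the chain would behave, such as morpholin-4-yl or dimethylamino, and what a longer chain between the oxygen and the pyrrolidin-1-yl ring would do.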